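Hydroxy in place of the aminomethylpiperidine on the phenol

The compounds below may be only part of what the source reports. "The series", "measured", "known", "first", "only" and "open" are said of these compounds alone.

Compound 1 `CC(C)=CCC[C@H](C)c1ccc(C)cc1O` gives 37200 nM in a functional assay on MDA-MB-231 cells (Homo sapiens), read by wound healing assay, with a stated time of 24 h; a higher number here means a weaker inhibitor, a lower number a stronger inhibitor. Compound 2 `CC(C)=CCC[C@H](C)c1ccc(C)c(CNCC2CCNCC2)c1O` reaches only a limit of this assay, > 20000 nM, as the limit of > 20000 nM in this assay, at which 1 of the 2 values shown sits, records. Compound 3 `CC(C)=CCC[C@H](C)c1ccc(C)c(CO)c1O` differs from compound 2 by hydroxy in place of ((piperidin-4-yl)methyl)amino on a saturated chain carbon bound to an aromatic carbon. Among the measured compounds shown here, no measured step between these compounds is available, and with compound 2 at a limit the expected change a step that the limit leaves unreadable from compound 2 to compound 3 is not seen as going beyond the usual scatter in either direction. Compound 3 is accordingly expected to give about 30000 nM in this assay, estimated between 8000 nM and 100000 nM, a weak inhibitor like compound 1 at 37200 nM.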

Compound 3, half-maximal inhibitory concentration: 12300 nM
Compound 3: middle estimate off by 2.4-fold (0.39 log units), on the high side; the range from low to high includes it.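

Hydroxymethyl in place of hydrogen on an aromatic carbon gives a 3.0-fold lower number from compound 1 to compound 3 (0.48 log units; beyond the scatter) in this assay, a modest step and the only readable one at this place. Hydroxy in place of ((piperidin-4-yl)methyl)amino on a saturated chain carbon bound to an aromatic carbon gives an at least 1.6-fold lower number from compound 2 to compound 3 (0.21 log units; that floor lies within the scatter), a floor that leaves the true size of this change unknown. Compound 2 stands at a limit: the limit of > 20000 nM in this assay, at which 1 of the 3 values shown sits.

Going by these compounds, whether a simple primary amine or a carboxylic acid on that carbon would keep this step remains open. So does the effect of a longer chain carrying the hydroxy.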